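A few compounds are considered here, and "the series" means these few. Any claim that something is new, unique, unknown or untested is made for them only; others in the source may bear on it.

Compound 1 `CC1=C(C(=O)Nc2ccc(F)cc2)C(c2ccc([N+](=O)[O-])cc2)N=C(SCc2cccc(Cl)c2)N1` and compound 2 `CC1=C(C(=O)Nc2ccc(F)cc2)C(c2ccc([N+](=O)[O-])cc2)N=C(SCc2ccc(Cl)cc2)N1` share one core; in a functional assay on the whole organism (artery, strain albino) with Rattus norvegicus as the target, with a stated time of 120 min, at a dose of 10 mg/kg by the oral route (a lower number here means less inhibition, a higher number more inhibition at the dose given (going by the name of the read-out)), compound 1 gives 9.8% and compound 2 gives 16%. The change between them is 4-chlorophenyl in place of 3-chlorophenyl on a saturated chain carbon bound to a sulfur, and the resulting step is a number 6.2 percentage points higher from compound 1 to compound 2 (within the scatter). Compound 3 `CC1=C(C(=O)Nc2ccc([N+](=O)[O-])cc2)C(c2cccc([N+](=O)[O-])c2)N=C(SCc2cccc(Cl)c2)N1` carries a different core, and the difference between the two cores is not broken down here; in this assay compound 3 gives 12.4%. Compound 4 `CC1=C(C(=O)Nc2ccc([N+](=O)[O-])cc2)C(c2cccc([N+](=O)[O-])c2)N=C(SCc2ccc(Cl)cc2)N1` is not yet measured and differs from compound 3 by 4-chlorophenyl in place of 3-chlorophenyl on a saturated chain carbon bound to a sulfur, the same change as that between compound 1 and compound 2, at the same place. For compound 4 the expected step in this assay is a number 5.6 percentage points higher from compound 3 to compound 4 (within the scatter), resting on the one earlier occurrence of this change, a number 6.2 percentage points higher from compound 1 to compound 2 (within the scatter). Compound 4 is accordingly estimated at 18% in this assay, within a range of 8% to 30%.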

Compound 4, a percentage reported as inhibition, in the whole organism at one dose (the size of the read-out at that dose, not a potency): 12.4%
The estimate for compound 4 lay 5.6 percentage points above the measured number, within the range that was stated.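

In this assay the exchange of 3-chlorophenyl for 4-chlorophenyl gives no change at the digits printed from compound 3 to compound 4 (within the scatter), and the two cores show no measurable difference in this step: the same change on two cores in this assay, a number 6.2 percentage points higher (within the scatter) from compound 1 to compound 2 and no change at the digits printed (within the scatter) from compound 3 to compound 4, 6.2 percentage points apart, within the scatter of two such steps. Within the data shown here, both steps lie within the scatter, so the agreement between them shows only that this change has no detectable effect on either core. It does not show that the change has a real effect that transfers from one core to the other, and two pairs of compounds give no rule for any further core.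

Still open, on these data alone, is whether an amine, a carboxylic acid or a longer chain in place of the chlorobenzyl group would move the read-out beyond the scatter.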